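Flipping One Stereocentre in Compound 1

The source may hold more compounds than are shown below. What is called first, only, known or untested is meant among the compounds shown, and "the series" means these compounds.

Among the compounds with values here, in a functional assay on A549 cells (Homo sapiens) for antiproliferative activity, read by MTT assay (a higher number here means a weaker inhibitor, a lower number a stronger inhibitor), compound 1 `CCCCC[C@@H](O)[C@H](O)/C=C/C(=O)N1CCCCC1` gives 135 ug/mL and so holds the only number available, which leaves nothing to rank it against. Compound 2 `CCC[C@@H](O)[C@H](O)/C=C/C(=O)NCC(C)C` was reported as "not active" (no number reported) and carries no number at all.

The next compound is a mirror-type change at one spot only. Compound 3 `CCCCC[C@@H](O)[C@@H](O)/C=C/C(=O)N1CCCCC1` relates to compound 1 as follows: the two compounds have the same atoms and bonds and differ only in configuration as drawn: 1 of 3 stereo elements differ; a stereocentre at a saturated chain carbon is drawn R in compound 1 and S in compound 3 and so the two have the same atoms and bonds and differ only in configuration as drawn, with a stereocentre at a saturated chain carbon drawn R in compound 1 and S in compound 3.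

Within the data shown here, no measured pair shows what such a flip does in this assay here, so neither direction can be favoured. With compound 1 at 135 ug/mL as the sole anchor, the expectation is no change beyond the usual scatter, though a large shift cannot be ruled out. The expected move is a 1.0-fold lower number from compound 1 to compound 3 (0.02 log units; within the scatter) in this estimate. For compound 3 the estimated value is 130 ug/mL with an expected range from 50 ug/mL to 350 ug/mL in all.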

Compound 3, half-maximal inhibitory concentration: 182 ug/mL
Compound 3: middle estimate off by 1.4-fold (0.15 log units), on the low side, within the range that was stated.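

In this assay, moving the stereocentre at a saturated chain carbon from R to S gives a 1.3-fold higher number from compound 1 to compound 3 (0.13 log units; within the scatter), so this read-out cannot tell the two compounds apart. Within the data shown here, this is the first measured pair in the set, and it gives the first direct reading of what this flip does: at this position, on these two compounds, the drawn configuration makes no difference that stands clear of the ordinary variation between repeated measurements. The comparison speaks to that one carbon alone, since nothing else separates the two structures, a point that rests on a single fact: the fact that compounds 1 and 3 differ only in the configuration as drawn

One pair on one core cannot show whether the same flip would read the same way on a different compound, or whether flipping either of the other two stereo elements, alone or together with this one, would give a step beyond the scatter. On these data alone, it also remains open how the core of compound 1 would respond to a different kind of change, such as a carboxylic acid or a longer chain, which would alter the atoms themselves rather than only their configuration.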